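A Methylsulfonyl Amide Tried Against Low Cytotoxicity

The source may report more compounds than this note shows. Statements on the series, on what has been measured and on what is new or still open speak of the compounds shown alone.

For the measured compounds named here, compound 2 `O=C(CCc1c(Cn2c(=O)n(C3CC3)c3ccncc32)nc2cc(Cl)ccn12)NCCO` is one of two compounds measured in an ADME assay on HEp-2 cells (Homo sapiens) for cytotoxicity, read by CCK-8 assay, with a stated time of 6 days; on this read-out lower numbers stand for higher toxicity in this test and higher numbers for lower toxicity in this test. In this assay compound 2 gives > 100000 nM, which is a limit of the assay and not a number. Its measured neighbour, compound 1 `CS(=O)(=O)CCNC(=O)c1c(Cn2c(=O)n(C3CC3)c3ccncc32)nc2cc(Cl)ccn12`, differs from it in one place. In this assay compound 1 gives > 100000 nM, also a limit rather than a number. The step that the two limits leave unreadable from compound 1 to compound 2 therefore cannot be read for size in either direction. Both values sit at the same limit, as shown by the limit of > 100000 nM in this assay, at which 2 of the 2 values shown sit. Compound 3 `CS(=O)(=O)NC(=O)CCc1c(Cn2c(=O)n(C3CC3)c3ccncc32)nc2cc(Cl)ccn12` has not yet been tested. The change from compound 2 is methylsulfonyl in place of 2-hydroxyethyl on an amide-type nitrogen. Going by the values given here, only one measured step bears on it and that step is unreadable, so nothing in the numbers points up or down; what is known is that both compounds measured so far sit at the limit. On that basis compound 3 is expected to stay at or beyond the limit, with the step that the limit leaves unreadable from compound 2 to compound 3 expected to be none beyond the scatter. The estimate for compound 3 in this assay is 150000 nM, expected to lie between 50000 nM and 500000 nM.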

Compound 3, half-maximal cytotoxic concentration: > 100000 nM
Compound 3: a limit, no number (the forecaster's own chance of this, stated with the estimate: 80%); the middle value does not contradict the limit.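

Compound 1, compound 2 and compound 3 all give a limit rather than a number in this assay, so no step among them can be read: the limit of > 100000 nM in this assay, at which 3 of the 3 values shown sit.

The compounds shown leave open how far apart their true values lie, and whether any change on the shared core would give a measurable cytotoxic concentration in this assay.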